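A few compounds are considered here, and "the series" means these few. Any claim that something is new, unique, unknown or untested is made for them only; others in the source may bear on it.

Compound 1 `CCCC(=O)Nc1cccc(NC(=O)COc2ccc3c(=O)ccoc3c2)c1` has the highest of the two numbers in an assay on isolated protein for inhibition of Rho-associated protein kinase 2 (Homo sapiens), read by scintillation counting, radiometric assay and 33P incorporation, with a stated time of 40 min, in the presence of a further agent that is not named here (a lower number here means a stronger inhibitor, a higher number a weaker inhibitor), where compound 1 gives 176 nM. Compound 2 `Cc1ccc(C(=O)Nc2cccc(NC(=O)COc3ccc4c(=O)ccoc4c3)c2)cc1` gives 22 nM, and the step of an 8.0-fold lower number from compound 1 to compound 2 (0.90 log units; beyond the scatter) came from 4-methylphenyl in place of propyl on the carbonyl carbon. Compound 3 `Nc1cccc(C(=O)Nc2cccc(NC(=O)COc3ccc4c(=O)ccoc4c3)c2)c1` has not been measured; its change from compound 1 is 3-aminophenyl in place of propyl on a carbonyl carbon. Among the compounds with values here, the single measured step bears directly on it, as both changes set a six-membered aromatic ring in place of propyl, so a lower number of similar size is expected; no measured step covers the amino group in place of methyl. The expected step is a 5.0-fold lower number from compound 1 to compound 3 (0.70 log units; beyond the scatter). Compound 3 is estimated at 35 nM, within 12 nM to 110 nM.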

Compound 3, half-maximal inhibitory concentration: 58 nM
Beside the measured number, compound 3's estimate is 1.7-fold (0.22 log units) below it; measured number inside the range.
By their numbers in this assay, from the lowest: compound 2; then compound 3; then compound 1.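

A six-membered aromatic ring on this carbonyl carbon lowers the number with an amino group as well as with a methyl group, so the gain over propyl is not unique to 4-methylphenyl (a 3.0-fold lower number from compound 1 to compound 3 (0.48 log units; beyond the scatter)). The choice of ring still matters: 3-aminophenyl in place of 4-methylphenyl gives a weaker inhibitor (a 2.6-fold higher number from compound 2 to compound 3 (0.42 log units; beyond the scatter)). Nothing available explains either step.

Compound 2 and compound 3 differ in both the ring's group and its place, so these two effects remain inseparable. A plain phenyl or 4-aminophenyl group would help to separate them.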